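Replacing the pyridinyl tail of compound 2 with a methylthiazolyl tail

The source may report more compounds than this note shows. Statements on the series, on what has been measured and on what is new or still open speak of the compounds shown alone.

The comparison rests on three measured compounds sharing one core. In an assay for inhibition of 15-hydroxyprostaglandin dehydrogenase [NAD(+)] (Homo sapiens), read by fluorescence and spectrophotometry (on this read-out lower numbers stand for stronger inhibition and higher numbers for weaker inhibition), compound 1 `O=C1N=C(O)S/C1=C\c1ccc(OCCc2ccsc2)cc1` gives 60 nM, compound 2 `O=C1N=C(O)S/C1=C\c1ccc(OCCc2ccccn2)cc1` gives 660 nM, and compound 3 `O=C1NC(=O)/C(=C/c2ccc(OCCC3CCCCO3)cc2)S1` gives 750 nM. Compound 2 thus holds the second highest of the three numbers; the gap to compound 3 lies within the scatter, whereas compound 1 sits well apart. For the measured compounds named here, the single one-place step available is an 11-fold higher number from compound 1 to compound 2 (1.04 log units; beyond the scatter), so exchanging the thiophen-3-yl tail for pyridin-2-yl cost a large amount of inhibition.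

The untested compound 4 `Cc1ncsc1CCOc1ccc(/C=C2\SC(O)=NC2=O)cc1` differs from compound 2 by 4-methyl-1,3-thiazol-5-yl in place of pyridin-2-yl on a saturated chain carbon, two bonds along the chain from an oxygen on an aromatic ring. Going by the values given here, the only step that bears on this change is the one from compound 1 to compound 2, which was large, and it ran from a five-membered sulfur-containing ring to a six-membered nitrogen-containing ring. Compound 4 returns to a five-membered ring that carries sulfur, though with an added nitrogen and a methyl group, so a move back toward the number of compound 1 is expected, likely only part of the way, with the step of a 3.3-fold lower number from compound 2 to compound 4 (0.52 log units; beyond the scatter) estimated. For compound 4 the expected value in this assay is 200 nM, with a range from 60 nM to 700 nM.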

Compound 4, half-maximal inhibitory concentration: 636 nM
Estimate against measurement, compound 4: 3.2-fold (0.50 log units) below, and the stated range covers the measured number.
By their numbers in this assay, from the lowest: compound 1; then compounds 4, 2 and 3 (each within the scatter of the next).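

In this assay the tail on the saturated chain carbon now has a second exchange to read: the step to 4-methyl-1,3-thiazol-5-yl, a 1.0-fold lower number from compound 2 to compound 4 (0.02 log units; within the scatter), leaves this tail and pyridin-2-yl level, so a five-membered aromatic ring containing sulfur was not enough to restore the inhibition seen with thiophen-3-yl. The direct comparison with that tail gives an 11-fold higher number from compound 1 to compound 4 (1.03 log units; beyond the scatter), a large step like an 11-fold higher number from compound 1 to compound 2 (1.04 log units; beyond the scatter), so among these three tails only thiophen-3-yl stands apart, and the two tails that carry nitrogen in the ring sit together at the weaker end. Nothing available gives a reason for this separation.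

The compounds shown leave open whether the loss with the thiazolyl tail follows from the ring nitrogen, from the methyl group or from both, which a 1,3-thiazol-5-yl tail without the methyl or a 3-methylthiophen-2-yl tail could begin to separate. They also leave open whether thiophen-3-yl is unusual at this position or whether a plain phenyl ring on the same chain would match it.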